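From ethoxycarbonyl to hydroxymethyl in a cytotoxicity series

The source may hold more compounds than are shown below. What is called first, only, known or untested is meant among the compounds shown, and "the series" means these compounds.

Within the data shown here, in a functional assay on K562 cells (Homo sapiens) for cytotoxicity, read by MTT assay, with a stated time of 48 h (a higher number here means a weaker inhibitor, a lower number a stronger inhibitor), compound 1 (`COc1cc([C@@H]2C[C@]2(CO)C(=O)Nc2ccccc2Cl)cc(OC)c1OC`) gives 16900 nM, the only full number in this small set. Compound 2 (`COc1cc([C@@H]2C[C@]2(CO)C(=O)NCc2ccc(C)cc2)cc(OC)c1OC`) reads > 100000 nM, which is a limit of the assay. Compound 3 (`CCOC(=O)[C@]1(C(=O)Nc2ccccc2)C[C@H]1c1cc(OC)c(OC)c(OC)c1`) reads > 100000 nM, also a limit and not a number. Compound 3 thus stands at the limit of > 100000 nM in this assay, at which 2 of the 3 values shown sit.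

Compound 4 (`COc1cc([C@@H]2C[C@]2(CO)C(=O)Nc2ccccc2)cc(OC)c1OC`) differs from compound 3 by hydroxymethyl in place of ethoxycarbonyl on a saturated ring carbon. Among the measured compounds shown here, no measured step covers this exchange directly. For the measured compounds named here, the one measured step lies elsewhere, on an amide-type nitrogen, where 4-methylbenzyl replaces 2-chlorophenyl: an at least 5.9-fold higher number from compound 1 to compound 2 (0.77 log units; beyond the scatter). It shows that hydroxymethyl does not guarantee a measurable value, since compound 2 also carries it. The expectation of a lower number in this assay rests on compound 1, which carries hydroxymethyl and gives 16900 nM. The expected change is an at least 2.5-fold lower number from compound 3 to compound 4 (0.39 log units; beyond the scatter), though compound 4 may yet stay at the limit. For compound 4 the estimate is 40000 nM, with an expected range of 12000 nM to 100000 nM.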

Compound 4, half-maximal inhibitory concentration: > 100000 nM
Compound 4 was reported as a limit (the forecaster's own chance of this, stated with the estimate: 35%); middle value at least 2.5-fold (0.39 log units) from the limit.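

Hydroxymethyl on the saturated ring carbon is not enough on its own for a measurable value in this assay, and compound 4 now shows this with a plain phenyl on the amide nitrogen, not only with the 4-methylbenzyl of compound 2. Among these compounds, with hydroxymethyl held in place, hydrogen in place of chloro on an aromatic carbon gives an at least 5.9-fold higher number from compound 1 to compound 4 (0.77 log units; beyond the scatter), so in this pair the chloro separates the one full number from a limit. The steps from compound 3 and from compound 2 to compound 4 cannot be read, and most of the set now sits at one limit: the limit of > 100000 nM in this assay, at which 3 of the 4 values shown sit.

Going by these compounds, whether ethoxycarbonyl and hydroxymethyl differ at all on this ring carbon stays open, as does whether chloro would bring a compound with ethoxycarbonyl off the limit. The compounds shown also do not tell what an aminomethyl group or a carboxylic acid on that carbon, or a bromo group in place of the chloro, would give.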